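Compound 3 to compound 4: a step among limits

The source may hold more compounds than are shown below. What is called first, only, known or untested is meant among the compounds shown, and "the series" means these compounds.

In an ADME assay on HepG2 cells (Homo sapiens) for cytotoxicity, with a stated time of 72 h (a higher number here means that more compound is needed for the effect, a lower number that less compound is needed), compound 3 `O=C(Nc1cccc(-c2nc3ccccc3o2)c1)c1cc([N+](=O)[O-])ccc1Cl` reports only a limit, > 25000 nM. Compound 1 `O=C(Nc1cccc(-c2nc3ccccc3s2)c1)c1cc([N+](=O)[O-])ccc1Cl` also reports only a limit, > 27000 nM. Compound 2 `O=C(Nc1cccc(-c2ccccc2)c1)c1cc([N+](=O)[O-])ccc1Cl` reports a limit too, > 27000 nM. Compound 4 `O=C(Nc1cccc(-c2nc3ccccc3[nH]2)c1)c1cc([N+](=O)[O-])ccc1Cl` puts 1H-benzimidazol-2-yl in place of 1,3-benzoxazol-2-yl on an aromatic carbon. Three measured steps change the group at this same place: a step that the two limits leave unreadable from compound 1 to compound 2, a step that the two limits leave unreadable from compound 1 to compound 3 and a step that the two limits leave unreadable from compound 2 to compound 3. None of them has a readable size, so they give only weak guidance. Going by these steps, no change beyond the scatter is expected in this assay, and another limit is the likeliest result. The expected change is a step that the limit leaves unreadable from compound 3 to compound 4. For compound 4 the estimate is 27000 nM, within an expected range of 12000 nM to 50000 nM.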

Compound 4, half-maximal effective concentration: > 27000 nM
Compound 4 gave a limit, no number (the forecaster's own chance of this, stated with the estimate: 75%); the middle value sits exactly at the limit.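

Compound 4 gives only a limit in this assay, so its steps from compound 1, compound 2 and compound 3 cannot be read, as all four values are limits. The compounds shown leave open how much compound any of these groups needs to reach the half-maximal effect.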